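The source may report more compounds than this note shows. Statements on the series, on what has been measured and on what is new or still open speak of the compounds shown alone.

Compound 1 `OC[C@H]1O[C@@H](n2cnc3c(NCc4ccc(Cl)cc4Cl)ncnc32)[C@H](O)[C@@H]1O`, compound 2 `OC[C@H]1O[C@@H](n2cnc3c(NCc4ccc(F)c(F)c4F)ncnc32)[C@H](O)[C@@H]1O` and compound 3 `OC[C@H]1O[C@@H](n2cnc3c(NCc4ccc(F)c(Cl)c4)ncnc32)[C@H](O)[C@@H]1O` share one core and differ only in the phenyl group on the chain. In a functional assay on HOS cells (Homo sapiens) for antiproliferative activity, with a stated time of 72 h (a higher number here means a weaker inhibitor, a lower number a stronger inhibitor), compound 1 gives > 166000 nM, which is a limit and not a number. Compound 2 gives > 166000 nM, also a limit. Compound 3 gives > 166000 nM, again only a limit, so the whole set reads: the limit of > 166000 nM in this assay, at which 3 of the 3 values shown sit.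

The measured steps are a step that the two limits leave unreadable from compound 1 to compound 2, a step that the two limits leave unreadable from compound 1 to compound 3 and a step that the two limits leave unreadable from compound 2 to compound 3. None of them offers a size to carry forward.

Compound 4 `Cc1ccc(O)c(CNc2ncnc3c2ncn3[C@@H]2O[C@H](CO)[C@@H](O)[C@H]2O)c1` has 2-hydroxy-5-methylphenyl in place of 3-chloro-4-fluorophenyl on a saturated chain carbon bound to a nitrogen on an aromatic ring. For the measured compounds named here, no measured step covers a swap of this kind, so the size of the change is uncertain.

An estimate can only start from compound 3 at > 166000 nM, a limit. The expected change is an at least 3.3-fold lower number from compound 3 to compound 4 (0.52 log units; beyond the scatter), a tentative lean towards a stronger value in this assay. For compound 4 the estimated value is 50000 nM, with an expected range from 5000 nM to 166000 nM.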

Compound 4, half-maximal inhibitory concentration: > 166000 nM
Compound 4 ended at the assay's limit; the forecaster's own chance of this, stated with the estimate: 40%; middle value at least 3.3-fold (0.52 log units) away from the limit.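

The steps from compound 1, compound 2 and compound 3 to compound 4 cannot be read, as all four compounds give only a limit in this assay: the limit of > 166000 nM in this assay, at which 4 of the 4 values shown sit.

The compounds shown leave open whether changing the phenyl group on the chain alters the result in this assay at all.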